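This account rests on a few compounds, and the source may have more. Where it says the series, first, only, none or still open, it means among the compounds named here.

Measured compounds in an assay on HEK-293T cells for antagonist activity at vitamin D3 receptor (Homo sapiens), read by a luciferase reporter, with a stated time of 24 h; a higher number here means a weaker inhibitor, a lower number a stronger inhibitor:
- compound 1, `CCn1c(-c2ccc(OCc3c(-c4c(Cl)cccc4Cl)noc3C(C)C)cc2)nc2ccc(C(=O)O)cc21`: 5760 nM
- compound 2, `CCCn1c(-c2ccc(OCc3c(-c4c(Cl)cccc4Cl)noc3C(C)C)cc2)nc2ccc(C(=O)O)cc21`: 1400 nM
- compound 3, `CC(C)c1onc(-c2c(Cl)cccc2Cl)c1COc1ccc(-c2nc3ccc(C(=O)O)cc3n2C2CC2)cc1`: 3200 nM

Compound 1 gives the highest number of the three in this assay. Its nearest neighbour is compound 3, with a 1.8-fold lower number from compound 1 to compound 3 (0.26 log units; within the scatter), a gap that sits within the usual scatter. The furthest is compound 2, with a 4.1-fold lower number from compound 1 to compound 2 (0.61 log units; beyond the scatter), a move beyond the scatter.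

Compound 4, `CC(C)c1onc(-c2c(Cl)cccc2Cl)c1COc1ccc(-c2nc3ccc(C(=O)O)cc3n2C2CCCCC2)cc1`, is not yet measured. It differs from compound 1 in one place: cyclohexyl in place of ethyl on an aromatic nitrogen

Both measured steps from compound 1 bear on this change, as each alters the group on the same aromatic nitrogen of the shared core. Methyl in place of hydrogen two bonds along the chain from the aromatic nitrogen gave a 4.1-fold lower number from compound 1 to compound 2 (0.61 log units; beyond the scatter), a modest move to a lower number; cyclopropyl in place of ethyl gave a 1.8-fold lower number from compound 1 to compound 3 (0.26 log units; within the scatter), within the scatter; and a 2.3-fold higher number from compound 2 to compound 3 (0.36 log units; beyond the scatter) separates the propyl and cyclopropyl analogues, a modest move in the other direction.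

Cyclohexyl brings a six-membered non-aromatic ring of carbon only, a group unlike either propyl or cyclopropyl, so the direction is not settled by the measured steps; a lower number than compound 1 seems somewhat more likely than a higher one. For compound 4 the expected step is a 2.9-fold lower number from compound 1 to compound 4 (0.46 log units; beyond the scatter). The estimate for compound 4 is 2000 nM, with a range from 600 nM to 7000 nM.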

Compound 4, half-maximal inhibitory concentration: 1450 nM
Estimate against measurement, compound 4: 1.4-fold (0.14 log units) above; the measured number falls inside the stated range.
By their numbers in this assay, from the lowest: compounds 2 and 4 (each within the scatter of the next); then compounds 3 and 1 (each within the scatter of the next).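

Cyclohexyl extends the series to a much larger ring on the aromatic nitrogen. In this assay it gives a 4.0-fold lower number from compound 1 to compound 4 (0.60 log units; beyond the scatter) and a 2.2-fold lower number from compound 3 to compound 4 (0.34 log units; beyond the scatter), whereas the smaller cyclopropyl ring had stayed within the scatter of ethyl. Ring and chain are not separated at the top of this small set, since a 1.0-fold higher number from compound 2 to compound 4 (0.02 log units; within the scatter) lies within the scatter, so propyl and cyclohexyl sit together and each stands beyond the scatter from both ethyl and cyclopropyl. No measurement here gives a reason for these steps.

Still open, on these data alone, is whether the number keeps falling or levels off with a longer chain such as butyl, with a branched isopropyl group, or with an intermediate cyclopentyl ring on the same nitrogen. Also open, as far as these compounds go, is how far this tolerance extends to groups that are not pure carbon, such as a piperidine ring with its amine or a cyclohexyl ring carrying a hydroxyl group.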